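A few compounds are considered here, and "the series" means these few. Any claim that something is new, unique, unknown or untested is made for them only; others in the source may bear on it.

Measured compounds:
Compound 1, `O=C(NCc1ccc(S(=O)(=O)C2CCCOC2)cc1)N1Cc2ccncc2C1`, gives 44 nM in an assay on isolated protein for inhibition of Nicotinamide phosphoribosyltransferase (Homo sapiens), read by mass spectrometry, with stated times of 15 min and 30 min; on this read-out lower numbers stand for stronger inhibition and higher numbers for weaker inhibition.
Compound 2, `CN1CCC(S(=O)(=O)c2ccc(CNC(=O)N3Cc4ccncc4C3)cc2)CC1`, gives 48 nM in this assay.
Compound 3, `O=C(NCc1ccc(S(=O)(=O)N2CCC(O)CC2)cc1)N1Cc2ccncc2C1`, gives 44 nM in this assay.

Compound 3 stands level with compound 1, the two together the lowest of the three numbers, and its gap to compound 2 is small: a 1.1-fold lower number from compound 2 to compound 3 (0.04 log units; within the scatter). The other exchanges on the sulfonyl sulfur were just as quiet, a 1.1-fold higher number from compound 1 to compound 2 (0.04 log units; within the scatter) and no change at the digits printed from compound 1 to compound 3 (within the scatter). Compound 4, `O=C(NCc1ccc(S(=O)(=O)N2CC3(CCOCC3)C2)cc1)N1Cc2ccncc2C1`, carries a further exchange at that same place: a group of 9 heavy atoms (7 carbon, 1 nitrogen, 1 oxygen; one four-membered non-aromatic ring with 1 hetero atom, one six-membered non-aromatic ring with 1 hetero atom) in place of a group of 7 heavy atoms (5 carbon, 1 nitrogen, 1 oxygen; one six-membered non-aromatic ring with 1 hetero atom), on a sulfonyl sulfur. Since every sulfonyl substituent change so far stayed within the scatter, the account expects no step beyond it in this assay, with a 1.1-fold higher number from compound 3 to compound 4 (0.06 log units; within the scatter) as the expected shift. Compound 4 is therefore estimated at 50 nM, with a range from 22 nM to 110 nM.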

Compound 4, half-maximal inhibitory concentration: 20 nM
Compound 4: the middle estimate sits 2.5-fold (0.40 log units) above what was measured; measured number outside the range, below it.
By their numbers in this assay, from the lowest: compound 4; then compounds 1, 3 and 2 (each within the scatter of the next).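

The position on the sulfonyl sulfur does respond to change. In this assay, within the data shown here, the entering group, with its one four-membered and one six-membered non-aromatic ring, is the first exchange there to pass the scatter (a 2.2-fold lower number from compound 3 to compound 4 (0.34 log units; beyond the scatter)), and it does so against each of the other groups as well (a 2.4-fold lower number from compound 2 to compound 4 (0.38 log units; beyond the scatter) and a 2.2-fold lower number from compound 1 to compound 4 (0.34 log units; beyond the scatter)). Nothing available here explains this step.

Going by these compounds, whether a plain azetidin-1-yl would do the same, or whether the six-membered ring joined to it is needed, stays open.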